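The source may report more compounds than this note shows. Statements on the series, on what has been measured and on what is new or still open speak of the compounds shown alone.

Measured so far in an ADME assay on MDCK cells (Canis lupus familiaris) for cytotoxicity, read by MTT assay, with a stated time of 48 h; on this read-out lower numbers stand for higher toxicity in this test and higher numbers for lower toxicity in this test:
compound 1 `CC1(C)[C@@H]2CC=C(COc3ccc4ccc(=O)oc4c3)[C@H]1C2` gives 7000 nM
compound 2 `CC1(C)[C@H]2CC=C(COc3ccc4ccc(=O)oc4c3)[C@@H]1C2` gives 310000 nM
compound 3 `CC1(C)[C@H]2CC=C(CCOc3ccc4ccc(=O)oc4c3)[C@@H]1C2` gives 10000 nM

Compound 1 stands at the low end of these numbers, level with compound 3 within the usual scatter, while compound 2 lies far higher. Compound 4 `Cc1cc(=O)oc2cc(OCC3=CC[C@@H]4C[C@H]3C4(C)C)ccc12` has not yet been measured. It departs from compound 1 in one place, by methyl in place of hydrogen on an aromatic carbon in all, which is methyl in place of hydrogen on an aromatic carbon, opposite the ring oxygen. Its configuration is that of compound 1.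

Within the data shown here, the only measured step that can be weighed is a 44-fold higher number from compound 1 to compound 2 (1.65 log units; beyond the scatter) and it is large, yet it rests on the fact that compounds 1 and 2 differ only in the configuration as drawn and involves no methyl. Compound 4 does not share that change of configuration, so the size of that step does not carry over. Among the measured compounds shown here, no measured pair shows what this methyl does, so the expectation in this assay is no step beyond the scatter in either direction, held with a wide margin. The expected step is a 1.1-fold higher number from compound 1 to compound 4 (0.06 log units; within the scatter) and it is only a cautious guess. For compound 4 the estimate is 8000 nM as the expected value, with 2500 nM to 30000 nM as its expected range.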

Compound 4, half-maximal cytotoxic concentration: 130000 nM
Compound 4: middle estimate off by 16-fold (1.21 log units), on the low side, outside the stated range (above it).
By their numbers in this assay, from the lowest: compounds 1 and 3 (each within the scatter of the next); then compound 4; then compound 2.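

In this assay, putting methyl in place of hydrogen on an aromatic carbon, opposite the ring oxygen, gives a 19-fold higher number from compound 1 to compound 4 (1.27 log units; beyond the scatter), so this position is not silent: one added carbon moves the number towards lower toxicity in this test. Among these compounds, the only large step seen earlier, a 44-fold higher number from compound 1 to compound 2 (1.65 log units; beyond the scatter), came with a change of configuration alone, whereas here the configuration of compound 1 is kept, so a change on the shared core alone can also produce a large step. Nothing at hand gives a cause for this step.

The compounds shown leave open whether another group in this place, such as ethyl, methoxy or chlorine, would move the number in the same direction and by a similar size, since methyl is the only group seen there. They also leave open whether the same methyl would produce a similar step on compound 2, whose number is already high, or on compound 3.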